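This account rests on a few compounds, and the source may have more. Where it says the series, first, only, none or still open, it means among the compounds named here.

Measured in a functional assay on MCF7 cells (Homo sapiens) for cytotoxicity, read by MTT assay, with a stated time of 72 h; on this read-out higher numbers stand for weaker inhibition and lower numbers for stronger inhibition:
- Compound 1 `Cc1ccc(-c2ccc(C(=O)Nc3ccc(Oc4ccnc5[nH]ccc45)c(F)c3)nc2)cc1`: 8020 nM
- Compound 2 `O=C(Nc1ccc(Oc2ccnc3[nH]ccc23)c(F)c1)c1cc(-c2ccccc2)ccn1`: > 10000 nM

Compound 2 gives only a limit of this assay, > 10000 nM, and not a number. Compound 3 `O=C(Nc1ccc(Oc2ccnc3[nH]ccc23)c(F)c1)c1cc(-c2ccc(F)cc2F)ccn1` is not yet measured. It differs from compound 2 by 2,4-difluorophenyl in place of phenyl on an aromatic carbon, with 2,4-difluorophenyl in place of phenyl on an aromatic carbon. Going by the values given here, no measured pair shows this change, so the expected step of an at least 1.1-fold lower number from compound 2 to compound 3 (0.04 log units; that floor lies within the scatter) is none beyond the scatter, in either direction. The expectation of a weak value also rests on compound 1, at 8020 nM. Compound 3 is expected at 9000 nM, with an estimated range of 4000 nM to 20000 nM.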

Compound 3, half-maximal inhibitory concentration: > 10000 nM
Compound 3: only a limit was reported; the forecaster's own chance of this, stated with the estimate: 55%; middle value at least 1.1-fold (0.04 log units) from the limit.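

Going by these compounds alone, compound 2 and compound 3 both give only a limit in this assay, and no step between them can be read. The compounds shown leave open whether 2,4-difluorophenyl in place of phenyl changes the read-out at all.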